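Working notes: pyridin-3-yl to cycloheptyl on the ring amine

The compounds below may be only part of what the source reports. "The series", "measured", "known", "first", "only" and "open" are said of these compounds alone.

Measured so far in an assay on CHO cells for displacement of a labelled ligand from adenosine receptor A1 (Homo sapiens), read by scintillation counting, with a stated time of 120 min, tested at 10 uM; on this read-out higher numbers stand for more inhibition at the one concentration tested (going by the name of the read-out) and lower numbers for less inhibition:
compound 1, `Nc1scc(CN2CCN(c3ccc([N+](=O)[O-])cc3)CC2)c1C(=O)c1ccc(Cl)cc1`, gives 1%
compound 2, `Nc1scc(CN2CCN(c3ccc(Cl)c(C(F)(F)F)c3)CC2)c1C(=O)c1ccc(Cl)cc1`, gives 0%
compound 3, `Nc1scc(CN2CCN(c3cccnc3)CC2)c1C(=O)c1ccc(Cl)cc1`, gives 0%

Compound 3 stands level with compound 2 at the digits given, the two together the lowest of the three numbers; compound 1 sits nearest above, and the gap is within the scatter. All three steps among the measured compounds are flat: a number 1 percentage points lower from compound 1 to compound 2 (within the scatter), a number 1 percentage points lower from compound 1 to compound 3 (within the scatter), and no change at the digits printed from compound 2 to compound 3 (within the scatter). Whatever group sits on the amine nitrogen in the ring, the shared core of compound 3 shows no inhibition to speak of in this assay.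

Compound 4, `Nc1scc(CN2CCN(C3CCCCCC3)CC2)c1C(=O)c1ccc(Cl)cc1`, is not yet measured. It differs from compound 3 thus: cycloheptyl in place of pyridin-3-yl on an amine nitrogen in a ring. Within the data shown here, no measured step swaps the group on that nitrogen for a non-aromatic ring of carbon only, so the three steps bear on this change only by showing that the position has been insensitive across three different groups, all within the scatter of one another.

Compound 4 is therefore expected to show no step beyond the scatter, the estimated change being a number 2 percentage points higher from compound 3 to compound 4 (within the scatter). In this assay compound 4 is estimated at 2%, with a range from -8% to 15%.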

Compound 4, a percentage reported as inhibition, at one concentration (the size of the read-out at that concentration, not a potency): 0%
For compound 4 the middle estimate is 2 percentage points above the measured one; the measured number falls inside the stated range.
By their numbers in this assay, from the lowest: compounds 2, 3, 4 and 1 (each within the scatter of the next).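

In this assay, a non-aromatic ring of carbon only now stands on the amine nitrogen in a ring, and the reading stays flat against all three aromatic groups: no change at the digits printed from compound 3 to compound 4 (within the scatter), no change at the digits printed from compound 2 to compound 4 (within the scatter) and a number 1 percentage points lower from compound 1 to compound 4 (within the scatter). The insensitivity of this position, so far seen only among aromatic groups, therefore extends to cycloheptyl, so that neither the six-membered aromatic ring nor the hydrogen-bond acceptor of pyridin-3-yl is needed for the reading seen with compound 3, and replacing them with a seven-membered ring of carbon only moves nothing beyond the scatter. No measurement at hand accounts for this flat reading.

Still open, as far as these compounds go, is whether a group of another kind on that nitrogen, such as a carboxylic acid or a longer chain ending in an amine, would lift the number in this assay at all. From the compounds shown here alone, all four compounds also keep the rest of the shared core unchanged, so the effect of replacing the chlorine on the benzoyl part, for instance with a methoxy group, remains open as well.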